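The compounds below may be only part of what the source reports. "The series", "measured", "known", "first", "only" and "open" are said of these compounds alone.

Compound 2 `CNC(=O)Nc1ccc(-c2nc(N3CC4CCC(C3)O4)c3cnn([C@H]4CC[C@@H](OC)CC4)c3n2)cc1` gives 0.283 h in an in vitro ADME assay on microsomes (Mus musculus) for metabolic stability (on this read-out higher numbers stand for a longer-lived compound and lower numbers for a shorter-lived compound), the highest of the two numbers at hand; compound 1 `CNC(=O)Nc1ccc(-c2nc(N3CC4CCC(C3)O4)c3cnn(CCN(C)C)c3n2)cc1` gives 0.0833 h, and the step of a 3.4-fold higher number from compound 1 to compound 2 (0.53 log units; beyond the scatter) describes that difference. Compound 3 `CNC(=O)Nc1ccc(-c2nc(N3CC4CCC(C3)O4)c3cnn([C@H]4CC[C@H](O)CC4)c3n2)cc1` is the next variation on the shared core, and it differs from compound 2 in one place: 4-hydroxycyclohexyl in place of 4-methoxycyclohexyl on an aromatic nitrogen. Within the data shown here, no measured step touches this same change, since the only step known, from compound 1 to compound 2, alters the whole group on the aromatic nitrogen rather than swapping methoxy for hydroxy on an otherwise identical ring. Without a comparable step, the expectation for compound 3 is a step of about a 1.2-fold higher number from compound 2 to compound 3 (0.09 log units; within the scatter), that is, no change beyond the scatter, with wide uncertainty. Compound 3 is therefore expected to give around 0.35 h, in a range from 0.12 h to 1 h.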

Compound 3, half-life: > 0.5 h
Compound 3: only a limit was reported (the forecaster's own chance of this, stated with the estimate: 5%); middle value at least 1.4-fold (0.15 log units) away from the limit.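

In this assay compound 3 is reported as a limit, > 0.5 h, and not as a number. Replacing 4-methoxycyclohexyl with 4-hydroxycyclohexyl gives an at least 1.7-fold higher number from compound 2 to compound 3 (0.24 log units; that floor lies within the scatter), so the hydrogen-bond donor that enters does not shorten the half-life, although this floor alone does not separate the two compounds beyond the scatter. Set against the 2-(dimethylamino)ethyl group, 4-hydroxycyclohexyl gives an at least 6.0-fold higher number from compound 1 to compound 3 (0.77 log units; beyond the scatter), so both cyclohexyl compounds shown, with either oxygen group, now outlast compound 1.

Going by these compounds, how far compound 3 really stands from compound 2 cannot be read from a limit: the limit of > 0.5 h in this assay, at which 1 of the 3 values shown sits. Also open is whether a plain cyclohexyl ring without oxygen, or a cyclohexyl ring carrying an amine, would last as long in this assay.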